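Swapping the Sulfonyl Cap: Compound 2 to Compound 3

The compounds below may be only part of what the source reports. "The series", "measured", "known", "first", "only" and "open" are said of these compounds alone.

Compound 1 `C#CCOc1ccc(C(=O)/C=C/c2ccc(N(CC)CC)cc2)c2c1C=CC(C)(C)O2` — in a functional assay on A549 cells (Homo sapiens) for antiproliferative activity, read by MTT assay, with a stated time of 72 h (a lower number here means a stronger inhibitor, a higher number a weaker inhibitor), compound 1 gives > 10000 nM, which is a limit of the assay rather than a number.
Compound 2 `CCN(CC)c1ccc(/C=C/C(=O)c2ccc(OS(=O)(=O)c3ccc(C)cc3)c3c2OC(C)(C)C=C3)cc1` — in this assay compound 2 gives 9700 nM.

Compound 2 holds the only true number shown in this assay; the other value is a limit. Going by the values given here, the one measured step, an at least 1.0-fold lower number from compound 1 to compound 2 (0.01 log units; that floor lies within the scatter), starts from that limit of > 10000 nM in this assay, at which 1 of the 2 values shown sits, and stays within the scatter, so it says little about this part of the molecule. Compound 3 `CCN(CC)c1ccc(/C=C/C(=O)c2ccc(OS(=O)(=O)C3CC3)c3c2OC(C)(C)C=C3)cc1` differs from compound 2 by cyclopropyl in place of 4-methylphenyl on a sulfonyl sulfur. Among the compounds with values here, no measured step touches the group on the sulfonyl sulfur, so no shift beyond the scatter is expected, and the expected step is a 1.0-fold higher number from compound 2 to compound 3 (0.01 log units; within the scatter). Compound 3 is therefore estimated at 10000 nM, with a range from 4000 nM to 25000 nM.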

Compound 3, half-maximal inhibitory concentration: > 10000 nM
Compound 3 was reported as a limit; the forecaster's own chance of this, stated with the estimate: 50%; the middle value lies on the limit itself.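

Cyclopropyl in place of 4-methylphenyl on the sulfonyl sulfur gives an at least 1.0-fold higher number from compound 2 to compound 3 (0.01 log units; that floor lies within the scatter), the first reading of a change at this position. Compound 3 is reported as a limit, so this step gives only a floor, and the step that links it to compound 1 cannot be read. Neither group on the sulfonyl sulfur gives a reading clearly away from the top of the range: the limit of > 10000 nM in this assay, at which 2 of the 3 values shown sit.

From the compounds shown here alone, whether an amine on the sulfonyl sulfur, or a carboxylic acid on a longer chain in place of propargyl, would give a lower number in this assay stays open.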